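Adding a methylsulfonyl-bearing group and its expected effect on solubility

A few compounds are considered here, and "the series" means these few. Any claim that something is new, unique, unknown or untested is made for them only; others in the source may bear on it.

Measured compounds:
Compound 1 `CCNC(=O)Nc1ccc(-c2nccc(C3=CCOCC3)n2)cc1`: 24 ug/mL
Compound 2 `CNCC(=O)Nc1ccc(-c2nc(C(C)(C)S(C)(=O)=O)cc([C@@]34CCOC[C@@H]3C4)n2)cc1`: 257 ug/mL
Compound 3 `CCNC(=O)Nc1ccc(-c2nccc([C@@]34CCOC[C@@H]3C4)n2)cc1`: 127 ug/mL

In a physicochemical assay for solubility, in phosphate buffer, measured as kinetic solubility, with a stated time of 1 h, at pH 7.4 (a higher number here means a more soluble compound, a lower number a less soluble compound), compound 3 stands second of the three numbers. For the measured compounds named here, it lies above compound 1, which gives 24 ug/mL, and the one measured step, a 5.3-fold higher number from compound 1 to compound 3 (0.72 log units; beyond the scatter), leads to it. Compound 2 gives 257 ug/mL, which is higher than compound 3.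

Compound 4 `CCNC(=O)Nc1ccc(-c2nc(C(C)(C)S(C)(=O)=O)cc([C@@]34CCOC[C@@H]3C4)n2)cc1` carries the change (1-methyl-1-(methylsulfonyl)ethyl in place of hydrogen on an aromatic carbon). Going by the values given here, no measured step isolates this change: the step from compound 1 to compound 3 concerns a different group on a different ring, so it does not bear on it. Among the compounds with values here, compound 2 is the only measured compound carrying 1-methyl-1-(methylsulfonyl)ethyl, but it also differs from compound 4 in its amide, so its value can only hint at the range.

Within the data shown here, with no direct precedent, a small rise in this assay is expected for compound 4, because compound 2 gives 257 ug/mL with the same group present. The expected step is a 1.3-fold higher number from compound 3 to compound 4 (0.10 log units; within the scatter). Compound 4 is therefore estimated at 160 ug/mL, within a range of 60 ug/mL to 400 ug/mL.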

Compound 4, solubility: 78 ug/mL
Compound 4: the middle estimate sits 2.1-fold (0.31 log units) above what was measured; measured number inside the range.
By their numbers in this assay, from the lowest: compound 1; then compounds 4 and 3 (each within the scatter of the next); then compound 2.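

In this assay, for the compounds shown here, the first isolated reading of 1-methyl-1-(methylsulfonyl)ethyl in place of hydrogen, on an aromatic carbon next to the ring nitrogen, is a 1.6-fold lower number from compound 3 to compound 4 (0.21 log units; within the scatter), so this large group leaves compound 3 and compound 4 indistinguishable. With that group held constant, the change on the carbonyl carbon, ethylamino in place of (methylamino)methyl, gives a 3.3-fold lower number from compound 2 to compound 4 (0.52 log units; beyond the scatter), so the high number of compound 2 cannot be read as a value for the sulfonyl-bearing group alone. Nothing shown gives a reason for either step.

On these data alone, whether a small group such as methyl, or an amine, on this same carbon would read differently stays open. So does how (methylamino)methyl reads with hydrogen on that carbon, and with it whether the two changes simply add.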